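The source may report more compounds than this note shows. Statements on the series, on what has been measured and on what is new or still open speak of the compounds shown alone.

Measured compounds in a functional assay on A-431 cells (Homo sapiens) for antiproliferative activity, read by sulforhodamine B assay, with a stated time of 72 h; a lower number here means a stronger inhibitor, a higher number a weaker inhibitor:
- compound 1 `COC(CCNC(=O)Nc1cc2c(Nc3ccc(F)c(Cl)c3)ncnc2cc1O[C@H]1CCOC1)OC`: 22000 nM
- compound 2 `CN(C)CCN(C)C(=O)Nc1cc2c(Nc3ccc(F)c(Cl)c3)ncnc2cc1O[C@H]1CCOC1`: 450 nM
- compound 3 `O=C(Nc1cc2c(Nc3ccc(F)c(Cl)c3)ncnc2cc1O[C@H]1CCOC1)N1CCC(F)CC1`: 3040 nM

Compound 1 stands at the highest number of the three; both replacements of its urea substituent gave lower numbers, by a 49-fold lower number from compound 1 to compound 2 (1.69 log units; beyond the scatter) and by a 7.2-fold lower number from compound 1 to compound 3 (0.86 log units; beyond the scatter), and the gap between those two is a 6.8-fold higher number from compound 2 to compound 3 (0.83 log units; beyond the scatter).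

Compound 4 `C#CCNC(=O)Nc1cc2c(Nc3ccc(F)c(Cl)c3)ncnc2cc1O[C@H]1CCOC1` differs from compound 1 by ethynyl in place of 2,2-dimethoxyethyl on a saturated chain carbon bound to an amide-type nitrogen. Among the compounds with values here, the three earlier steps, all at this same urea substituent, bear on it: each departure from the (3,3-dimethoxypropyl)amino group lowered the number, but no measured compound carries a propargyl group, so the size is uncertain. A modest step downward is expected, a 3.1-fold lower number from compound 1 to compound 4 (0.50 log units; beyond the scatter).

The estimate for compound 4 in this assay is therefore 7000 nM, with a range of 2000 nM to 22000 nM.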

Compound 4, half-maximal inhibitory concentration: 3730 nM
Compound 4: middle estimate off by 1.9-fold (0.27 log units), on the high side; the range from low to high includes it.
By their numbers in this assay, from the lowest: compound 2; then compounds 3 and 4 (each within the scatter of the next); then compound 1.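

In this assay the ethynyl change keeps the urea's amide hydrogen and still lowers the number (a 5.9-fold lower number from compound 1 to compound 4 (0.77 log units; beyond the scatter)), so a drop from compound 1 does not depend on a fully substituted urea nitrogen. Propargylamino and 4-fluoropiperidin-1-yl cannot be told apart here (a 1.2-fold higher number from compound 3 to compound 4 (0.09 log units; within the scatter)). The (2-(dimethylamino)ethyl)(methyl)amino group of compound 2 keeps its lead over the propargylamino group (an 8.3-fold higher number from compound 2 to compound 4 (0.92 log units; beyond the scatter)).

From the compounds shown here alone, whether a longer alkyne chain or a carboxylic acid at this carbon would move the number further remains open. No measurement here explains any of these steps.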